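Adding a Second Chloro to the Benzyl Ring of Compound 3

A few compounds are considered here, and "the series" means these few. Any claim that something is new, unique, unknown or untested is made for them only; others in the source may bear on it.

Compound 1 `CCCn1c(=O)c2nc(-c3cnn(Cc4cc(C(F)(F)F)ccc4Cl)c3)[nH]c2n(CCC)c1=O`: 1200 nM
Compound 2 `CCCn1c(=O)c2nc(-c3cnn(Cc4cc(F)ccc4Cl)c3)[nH]c2n(CCC)c1=O`: "not determined" (no result reported)
Compound 3 `CCCn1c(=O)c2nc(-c3cnn(Cc4cccc(Cl)c4)c3)[nH]c2n(CCC)c1=O`: 31 nM

In an assay on CHO cells for displacement of a labelled ligand from adenosine receptor A1 (Homo sapiens) (a lower number here means a stronger inhibitor, a higher number a weaker inhibitor), compound 3 gives the lowest of the two reported numbers; compound 1 is the nearest, and compound 2 has no reported number. Compound 4 `CCCn1c(=O)c2nc(-c3cnn(Cc4cc(Cl)ccc4Cl)c3)[nH]c2n(CCC)c1=O` differs from compound 3 by chloro in place of hydrogen on an aromatic carbon. Going by the values given here, the only measured step that bears on this is a 39-fold lower number from compound 1 to compound 3 (1.59 log units; beyond the scatter), which replaced 2-chloro-5-(trifluoromethyl)phenyl with 3-chlorophenyl. Compound 4, as 2,5-dichlorophenyl, stands between compound 1 and compound 3 in structure, so part of that large loss is expected to return. Compound 4 is expected to show a 4.8-fold higher number from compound 3 to compound 4 (0.68 log units; beyond the scatter), with an estimated 150 nM and a range from 40 nM to 600 nM.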

Compound 4, inhibition constant: 190 nM
Estimate against measurement, compound 4: 1.3-fold (0.10 log units) below; low and high end bracket the measured number.
By their numbers in this assay, from the lowest: compound 3; then compound 4; then compound 1.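

In this assay, chloro on the aromatic carbon ortho to a large group and para to a chloro group weakens compound 3 on its own, giving a 6.1-fold higher number from compound 3 to compound 4 (0.79 log units; beyond the scatter). Chloro in place of trifluoromethyl accounts for the rest of the earlier loss, giving a 6.3-fold lower number from compound 1 to compound 4 (0.80 log units; beyond the scatter), so the large step divides into two parts, each beyond the scatter. No measurement here explains either part. From the compounds shown here alone, whether methyl or methoxy in place of the added chloro would be tolerated remains open, as does the effect of an amine there.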